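A few compounds are considered here, and "the series" means these few. Any claim that something is new, unique, unknown or untested is made for them only; others in the source may bear on it.

Measured compounds:
Compound 1, `O=C(COc1ccc(C2CCCCC2)cc1)Nc1cccc(-c2nc3ncccc3o2)c1`, 2600 nM in an assay on brain for inhibition of Fatty-acid amide hydrolase 1 (Rattus norvegicus); a higher number here means a weaker inhibitor, a lower number a stronger inhibitor.
Compound 2, `O=C(COc1ccc(-c2ccccc2)cc1)Nc1ccc(-c2nc3ncccc3o2)cc1`, 350 nM in this assay.
Compound 3, `O=C(COc1ccc(C2CCCCC2)cc1)Nc1cccc(-c2nc3ncccc3[nH]2)c1`, 47000 nM in this assay.

Compound 2 gives the lowest number of the three. The difference between the cores of compound 1 and compound 2 is not broken down here. Compound 3 differs from compound 1 by a group of 9 heavy atoms (6 carbon, 3 nitrogen; one five-membered aromatic ring with 2 hetero atoms, one six-membered aromatic ring with 1 hetero atom) in place of a group of 9 heavy atoms (6 carbon, 2 nitrogen, 1 oxygen; one five-membered aromatic ring with 2 hetero atoms, one six-membered aromatic ring with 1 hetero atom), on an aromatic carbon, and this change gave an 18-fold higher number from compound 1 to compound 3 (1.26 log units; beyond the scatter).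

Compound 4, `O=C(COc1ccc(-c2ccccc2)cc1)Nc1ccc(-c2nc3ncccc3[nH]2)cc1`, has not yet been measured. It differs from compound 2 by a group of 9 heavy atoms (6 carbon, 3 nitrogen; one five-membered aromatic ring with 2 hetero atoms, one six-membered aromatic ring with 1 hetero atom) in place of a group of 9 heavy atoms (6 carbon, 2 nitrogen, 1 oxygen; one five-membered aromatic ring with 2 hetero atoms, one six-membered aromatic ring with 1 hetero atom), on an aromatic carbon. This is the same kind of change as from compound 1 to compound 3, though there the new group sits meta to a large group and here para to a large group. For the measured compounds named here, compound 4 is expected to show a step of an 18-fold higher number from compound 2 to compound 4 (1.26 log units; beyond the scatter) in this assay, resting on the single earlier step of an 18-fold higher number from compound 1 to compound 3 (1.26 log units; beyond the scatter). Compound 4 is thus estimated at 6300 nM, between 2000 nM and 20000 nM.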

Compound 4, half-maximal inhibitory concentration: 620 nM
Estimate against measurement, compound 4: 10-fold (1.01 log units) above; measured number outside the range, below it.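

In this assay, the same exchange of groups on the core of compound 2 gave a 1.8-fold higher number from compound 2 to compound 4 (0.25 log units; within the scatter), so the size of the step did not carry over from one core to the other: the same change on two cores in this assay, an 18-fold higher number (1.26 log units; beyond the scatter) from compound 1 to compound 3 and a 1.8-fold higher number (0.25 log units; within the scatter) from compound 2 to compound 4, 10-fold (1.01 log units) apart, beyond the scatter of two such steps The large step seen on the core of compound 1 therefore cannot serve as a general rule for this series. For the compounds shown here, it does not show which feature sets the size of the step, as the two cores differ in more than one place and only two pairs are available.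

The compounds shown leave open how this exchange would behave on further cores. They also leave open how an amine or a carboxylic acid at the same place would compare.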